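Swapping the amine-bearing group on a carbonyl carbon

This account rests on a few compounds, and the source may have more. Where it says the series, first, only, none or still open, it means among the compounds named here.

- compound 1 (`CC(C)C[C@@H](N)C(=O)Nc1cc2cc[nH]c(=O)c2cc1Cl`) gives 0.267 h
- compound 2 (`O=C(Nc1cc2cc[nH]c(=O)c2cc1Cl)[C@@H]1CCCN1`) gives 0.267 h

Among the compounds with values here, in an in vitro ADME assay on microsomes from liver (Homo sapiens) for metabolic stability, tested at 1 mg/mL (on this read-out higher numbers stand for a longer-lived compound and lower numbers for a shorter-lived compound), compound 2 stands at 0.267 h and so sits level with compound 1, the only other compound measured so far. The compound now awaiting measurement is compound 3 (`N[C@H]1CC[C@@H](C(=O)Nc2cc3cc[nH]c(=O)c3cc2Cl)CC1`). It differs from compound 2 by a single exchange (4-aminocyclohexyl in place of pyrrolidin-2-yl on a carbonyl carbon), in which 4-aminocyclohexyl comes in place of pyrrolidin-2-yl on a carbonyl carbon, while the core stays the same.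

Within the data shown here, only one measured step bears on this exchange. It is no change at the digits printed from compound 1 to compound 2 (within the scatter) and it concerns the same place, where pyrrolidin-2-yl came in place of 1-amino-3-methylbutyl. Among the measured compounds shown here, that single step is thin evidence, and no measured compound carries a six-membered ring at this place, so the data point in neither direction. Resting on no change at the digits printed from compound 1 to compound 2 (within the scatter) as the only guide, the account expects no shift beyond the scatter. The expected step is a 1.1-fold higher number from compound 2 to compound 3 (0.05 log units; within the scatter) and it could fall either way. For compound 3 the estimated half-life is 0.3 h with an expected range from 0.15 h to 0.7 h as its limits.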

Compound 3, half-life: 1.17 h
The estimate for compound 3 lay 3.9-fold (0.59 log units) below the measured number, outside the stated range (above it).
By their numbers in this assay, from the lowest: compounds 1 and 2 (each within the scatter of the next); then compound 3.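

In this assay, the place on the carbonyl carbon no longer looks indifferent to the group it carries: 4-aminocyclohexyl in place of pyrrolidin-2-yl gives a 4.4-fold higher number from compound 2 to compound 3 (0.64 log units; beyond the scatter) and, in place of 1-amino-3-methylbutyl, gives a 4.4-fold higher number from compound 1 to compound 3 (0.64 log units; beyond the scatter) as the same exchange read from the other starting point. The open-chain and five-membered groups of compound 1 and compound 2 stand level, so among these three compounds only the six-membered carbon ring of compound 3 separates from the rest. Nothing measured here accounts for that difference.

The compounds shown leave open whether the longer half-life goes with the cyclohexyl ring itself or needs its amine, which a plain cyclohexyl group or a piperidin-4-yl ring carrying its nitrogen within the ring could help to separate. They also leave open whether the two defined stereocentres of 4-aminocyclohexyl matter, a question for the same group with the opposite arrangement at those centres, and whether moving the amine elsewhere on the ring would keep the number where compound 3 puts it.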